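Swapping the Dibromophenol for a Bromoanisole on the Amide

The compounds below may be only part of what the source reports. "The series", "measured", "known", "first", "only" and "open" are said of these compounds alone.

Compound 1 `O=C(Nc1ccc(Sc2nc3ccccc3s2)cc1)c1cc(Br)cc(Br)c1O` has been tested in an ADME assay on FHC cells (Homo sapiens) for cytotoxicity, read by resazurin assay, with a stated time of 48 h (on this read-out higher numbers stand for lower toxicity in this test and lower numbers for higher toxicity in this test), where compound 1 gives 74000 nM. Among the measured compounds shown here, that is the only plain number so far; the other value is a limit. Compound 2 `COc1ccc(S(=O)(=O)Nc2ccc3oc(-c4ccc(NS(=O)(=O)c5cc(Br)ccc5OC)cc4)nc3c2)cc1` returns only a limit in this assay, > 100000 nM. This matches (the limit of > 100000 nM in this assay, at which 1 of the 2 values shown sits).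

Compound 3 `COc1c(Br)cccc1C(=O)Nc1ccc(Sc2nc3ccccc3s2)cc1` differs from compound 1 in one place: a group of 9 heavy atoms (7 carbon, 1 oxygen, 1 bromine; one six-membered aromatic ring of carbon only) in place of a group of 9 heavy atoms (6 carbon, 1 oxygen, 2 bromine; one six-membered aromatic ring of carbon only), on a carbonyl carbon. For the measured compounds named here, no step between measured compounds exists, so the expected size of the move rests on this change alone; a small shift toward lower toxicity is expected, near the edge of the scatter. Compound 3 is estimated at 95000 nM, with a range from 40000 nM to 200000 nM. The expected step is a 1.3-fold higher number from compound 1 to compound 3 (0.11 log units; within the scatter).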

Compound 3, half-maximal cytotoxic concentration: > 100000 nM
Compound 3 was reported as a limit; the forecaster's own chance of this, stated with the estimate: 40%; middle value at least 1.0-fold (0.02 log units) away from the limit.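

On the carbonyl carbon, putting a ring with one bromine and no hydrogen-bond donor in place of 3,5-dibromo-2-hydroxyphenyl gives an at least 1.3-fold higher number from compound 1 to compound 3 (0.13 log units; that floor lies within the scatter). In this assay compound 3 gives > 100000 nM, which is a limit of the assay and not a number. The swap therefore does not bring the number down, but the true size of the step stays unknown, since the read-out stops here: the limit of > 100000 nM in this assay, at which 2 of the 3 values shown sit.

On these data alone, whether the lost hydrogen-bond donor or the lost bromine matters more remains open, as both change together in this one step. As far as these compounds go, how an amine or a carboxylic acid on this carbonyl carbon would read in this assay also remains open.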